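Triazole-linked diaryl ureas: swapping the terminal aryl group

The compounds below may be only part of what the source reports. "The series", "measured", "known", "first", "only" and "open" are said of these compounds alone.

In a functional assay on HT-29 cells (Homo sapiens) for antiproliferative activity, read by MTT assay, with a stated time of 72 h (on this read-out higher numbers stand for weaker inhibition and lower numbers for stronger inhibition), compound 1 `Cn1ncnc1-c1cc(Oc2ccc(NC(=O)Nc3cccc(C(F)(F)F)c3)cc2F)ccn1` gives > 50000 nM. In this assay compound 2 `CN(C)CCn1cnnc1-c1cc(Oc2ccc(NC(=O)Nc3cccc(C(F)(F)F)c3)cc2F)ccn1` gives 1470 nM. In this assay compound 3 `CCN(CC)CCn1cnnc1-c1cc(Oc2ccc(NC(=O)Nc3cccc(C(F)(F)F)c3)cc2F)ccn1` gives 630 nM.

The value of compound 1 is a limit of this assay and not a number, as the limit of > 50000 nM in this assay, at which 1 of the 3 values shown sits, records. Compound 3 stands lowest of the two numbers shown; its nearest neighbour is compound 2, and the step of a 2.3-fold lower number from compound 2 to compound 3 (0.37 log units; beyond the scatter) lies beyond the scatter. The steps of an at least 34-fold lower number from compound 1 to compound 2 (1.53 log units; beyond the scatter) and an at least 79-fold lower number from compound 1 to compound 3 (1.89 log units; beyond the scatter) show how much the aminoethyl side chains on the shared core change the read-out.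

Compound 4 `CCN(CC)CCn1cnnc1-c1cc(Oc2ccc(NC(=O)Nc3ccc(Cl)cc3Cl)cc2F)ccn1` differs from compound 3 in one place: 2,4-dichlorophenyl in place of 3-(trifluoromethyl)phenyl on an amide-type nitrogen. For the measured compounds named here, none of the measured steps touches this part of the molecule; all three concern the triazole side chain, so they bear on the change to compound 4 only as a sign that this series responds to structural change. Going by the values given here, with no direct precedent, compound 4 is expected to give 1200 nM (range 300 nM to 5000 nM), an estimated step of a 1.9-fold higher number from compound 3 to compound 4 (0.28 log units; within the scatter) that may lie within the scatter.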

Compound 4, half-maximal inhibitory concentration: 3590 nM
Compound 4: middle estimate off by 3.0-fold (0.48 log units), on the low side, and the stated range covers the measured number.
By their numbers in this assay, from the lowest: compound 3; then compound 2; then compound 4. At a limit, above all of these: compound 1.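

The earlier steps all lay in the triazole side chain, so this is the only step shown at the aryl group on the amide-type nitrogen, and in this assay the exchange of 3-(trifluoromethyl)phenyl for 2,4-dichlorophenyl gives a 5.7-fold higher number from compound 3 to compound 4 (0.76 log units; beyond the scatter) with the diethylamino side chain held constant. This position therefore affects the read-out beyond the scatter, and the change runs in the opposite direction to a 2.3-fold lower number from compound 2 to compound 3 (0.37 log units; beyond the scatter) in the side chain. Nothing among the data shown accounts for this step through a measured property.

The step replaces one aryl group with another that differs in both its substituents and their places, so the compounds shown cannot assign the change to either. A 4-chlorophenyl or 2-chlorophenyl group at this nitrogen would separate these, and the same exchange with the dimethylamino side chain of compound 2 would test whether the step carries over.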